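A few compounds are considered here, and "the series" means these few. Any claim that something is new, unique, unknown or untested is made for them only; others in the source may bear on it.

In a functional assay on HCC827 cells (Homo sapiens) for inhibition, read by fluorescence, with a stated time of 72 h (on this read-out lower numbers stand for stronger inhibition of growth and higher numbers for weaker inhibition of growth), compound 1 (`CC(C)CCn1cnc2c(Nc3ccc(Cl)cc3)nc(N[C@H]3CC[C@H](N)CC3)nc21`) gives 10200 nM, compound 2 (`CC(C)CCn1cnc2c(Nc3cccc(Cl)c3)nc(N[C@H]3CC[C@H](N)CC3)nc21`) gives 10300 nM and compound 3 (`CC(C)CCn1cnc2c(Nc3ccccc3)nc(N[C@H]3CC[C@H](N)CC3)nc21`) gives 21700 nM. Compound 3, with no substituent on the anilino ring, thus has the highest number of the three and the weakest growth inhibition. Moving the chloro shows no change beyond the scatter: a 1.0-fold higher number from compound 1 to compound 2 (0.00 log units; within the scatter).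

Compound 4 (`CC(C)CCn1cnc2c(Nc3cccc(O)c3)nc(N[C@H]3CC[C@H](N)CC3)nc21`) has hydroxy in place of hydrogen on an aromatic carbon, phenyl to 3-hydroxyphenyl: hydroxy in place of hydrogen on an aromatic carbon. Among the compounds with values here, no hydroxy compound has been measured, so the nearest evidence is the pair of chloro steps, read in reverse. These are a 2.1-fold higher number from compound 2 to compound 3 (0.32 log units; beyond the scatter) and a 2.1-fold higher number from compound 1 to compound 3 (0.33 log units; beyond the scatter), both modest. The step from compound 2 carries the most weight, as its chloro occupies the same ring position as the new hydroxy. A small move toward a lower number is therefore expected, though hydroxy need not match chloro. The expected change is a 1.7-fold lower number from compound 3 to compound 4 (0.22 log units; within the scatter), which may not clear the scatter. The estimate for compound 4 is 13000 nM, with an expected range of 5000 nM to 30000 nM.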

Compound 4, concentration for 50% growth inhibition: 21300 nM
Compound 4: middle estimate off by 1.6-fold (0.21 log units), on the low side; the measured number falls inside the stated range.
By their numbers in this assay, from the lowest: compounds 1 and 2 (each within the scatter of the next); then compounds 4 and 3 (each within the scatter of the next).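

In this assay hydroxy at this position, on an aromatic carbon meta to a large group, does not repeat what chloro does: the change from the unsubstituted phenyl gives a 1.0-fold lower number from compound 3 to compound 4 (0.01 log units; within the scatter) and leaves compound 4 level with compound 3, while the chloro comparison gives a 2.1-fold higher number from compound 2 to compound 4 (0.32 log units; beyond the scatter) and the comparison with the 4-chlorophenyl compound gives a 2.1-fold higher number from compound 1 to compound 4 (0.32 log units; beyond the scatter) as well. Among the compounds shown, a substituent on this ring therefore does not by itself separate a compound from compound 3, and compound 4 goes against any such reading. No measured data here explain the gap between hydroxy and chloro at this position.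

Open, on these data alone, is whether 3-methoxyphenyl, 3-aminophenyl or 3-bromophenyl would fall with the chloro compounds or with compound 4. Within the data shown here, also open is whether the same gap between hydroxy and chloro would hold with a longer chain in place of the one shared by these compounds.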